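The source may report more compounds than this note shows. Statements on the series, on what has been measured and on what is new or still open speak of the compounds shown alone.

Compound 1 `CCCCCCCCCCCCCCNc1nc(SCc2ccc(C(F)(F)F)cc2)nc2ccccc12` — > 50000 nM
Compound 2 `FC(F)(F)c1ccc(CSc2nc(Nc3ccccc3)c3ccccc3n2)cc1` — 26400 nM

Both compounds were run in a functional assay on HGC-27 cells (Homo sapiens) for cytotoxicity, read by MTT assay, with a stated time of 72 h; on this read-out higher numbers stand for weaker inhibition and lower numbers for stronger inhibition. Compound 1 shows only > 50000 nM, which is a limit of the assay and not a number, the case described by the limit of > 50000 nM in this assay, at which 1 of the 2 values shown sits. For the measured compounds named here, compound 2 gives 26400 nM in this assay, the single measured number among the two, and so stands as the one compound for which a value is actually known. Compound 3 `FC(F)(F)c1ccc(CSc2nc(Nc3cccc(C(F)(F)F)c3)c3ccccc3n2)cc1` differs from compound 2 by trifluoromethyl in place of hydrogen on an aromatic carbon. Going by the values given here, no measured pair differs in one place, so no step size can be drawn from the data. A step of this kind is expected to stay within the usual scatter of this assay, with no clear direction. The step from compound 2 to compound 3 is estimated at a 1.3-fold lower number from compound 2 to compound 3 (0.12 log units; within the scatter). Compound 3 is therefore expected to give about 20000 nM, with a likely range from 6000 nM to 60000 nM.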

Compound 3, half-maximal inhibitory concentration: 11700 nM
Compound 3: the middle estimate sits 1.7-fold (0.23 log units) above what was measured, within the range that was stated.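

With this result the series has its first readable single-place change: in this assay trifluoromethyl in place of hydrogen on an aromatic carbon of the anilino ring gives a 2.3-fold lower number from compound 2 to compound 3 (0.35 log units; beyond the scatter). For the compounds shown here, the step is modest but lies beyond the scatter, so this carbon, meta to a large group, is a place where a substituent can shift the number, which the earlier compounds, differing in no single place, could not show. Nothing measured here bears on the reason for this shift.

As far as these compounds go, it remains open whether a chlorine atom, a methoxy group or a carboxylic acid in the same place would move the number in the same direction. From the compounds shown here alone, it also remains open whether trifluoromethyl would have a similar effect on another carbon of this ring.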